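Ethoxy for tetrazolyl on the benzamide of compound 1

A few compounds are considered here, and "the series" means these few. Any claim that something is new, unique, unknown or untested is made for them only; others in the source may bear on it.

Measured compounds:
- compound 1 `Cc1c(C#N)ccnc1O[C@@H]1CC[C@@H](C)N(C(=O)c2ccccc2-n2ncnn2)C1`: 1.6 nM
- compound 2 `COc1ccc(C(=O)N2C[C@H](Oc3nccc(C#N)c3C)CC[C@H]2C)c(SC)n1`: 2 nM

In an assay on cells for displacement of a labelled ligand from Orexin receptor type 2 (Homo sapiens) (a lower number here means a stronger inhibitor, a higher number a weaker inhibitor), compound 1 gives the lowest of the two numbers. Compound 2 gives a number within the scatter of that of compound 1, so the two cannot be told apart on these data. Compound 3 `CCOc1ccccc1C(=O)N1C[C@H](Oc2nccc(C#N)c2C)CC[C@H]1C` has not yet been measured in this assay. Compound 3 differs from compound 1 at one place on the aryl ring of the amide: ethoxy in place of 2H-tetrazol-2-yl on an aromatic carbon. Going by the values given here, no step between measured compounds bears on this change, so there is nothing direct to build on. Because compound 1 already sits at 1.6 nM, and compound 2 shows that a different amide aryl also reaches 2 nM, the expectation is a modest loss, estimated as a 3.1-fold higher number from compound 1 to compound 3 (0.49 log units; beyond the scatter), though a result within the scatter is possible. Compound 3 is therefore expected to give about 5 nM, in the range 1.5 nM to 20 nM.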

Compound 3, inhibition constant: 0.7 nM
For compound 3 the middle estimate is 7.1-fold (0.85 log units) above the measured one; measured number outside the range, below it.
By their numbers in this assay, from the lowest: compound 3; then compounds 1 and 2 (each within the scatter of the next).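

In this assay, the aryl position ortho to a large group does not need 2H-tetrazol-2-yl: ethoxy in its place gives a 2.3-fold lower number from compound 1 to compound 3 (0.36 log units; beyond the scatter). A five-membered aromatic ring with 4 hetero atoms is therefore not required at this position for a low number, and a smaller substituent with no ring and fewer hydrogen-bond acceptors is tolerated in the core of compound 1. No measurement bears on why the number falls with this change.

From the compounds shown here alone, it remains open whether the step follows the ether oxygen or the ethyl chain, a question that methoxy, propoxy or a plain ethyl group on the same aromatic carbon could address. Going by these compounds, how far this position accepts other kinds of group, such as a dimethylamino group or a carboxylic acid, also remains open.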